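Swapping the fused pyrazole for a trifluoromethyl pyrazole

The source may report more compounds than this note shows. Statements on the series, on what has been measured and on what is new or still open speak of the compounds shown alone.

Measured so far:
Compound 1 `O=C(O)CCNC(=O)c1ccc(C(Oc2ccc(-n3cc(C(F)(F)F)cn3)cc2)C2CC2)cc1` gives 1300 nM in an assay on cells for displacement of a labelled ligand from Glucagon receptor (Homo sapiens), in the presence of a further agent that is not named here; a higher number here means a weaker inhibitor, a lower number a stronger inhibitor.
Compound 2 `CCCC(Oc1ccc(-n2cc3c(n2)CCCC3)cc1)c1ccc(C(=O)NCCC(=O)O)cc1` gives 690 nM in this assay.
Compound 3 `CCCC(Nc1ccc(-n2cnc(C(F)(F)F)c2)cc1)c1ccc(C(=O)NCCC(=O)O)cc1` gives 680 nM in this assay.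

Among these three numbers compound 2 stands second highest. Its nearest neighbour is compound 3, whose value sits a hair lower, a gap well within the scatter of repeated measurements. Its furthest neighbour is compound 1, whose number is higher, but even that gap stays within the scatter, so none of the three can be called the stronger or weaker inhibitor on this evidence.

Compound 4 `CCCC(Oc1ccc(-n2cc(C(F)(F)F)cn2)cc1)c1ccc(C(=O)NCCC(=O)O)cc1` has not been measured. It differs from compound 2 in one place: a group of 9 heavy atoms (4 carbon, 2 nitrogen, 3 fluorine; one five-membered aromatic ring with 2 hetero atoms) in place of a group of 9 heavy atoms (7 carbon, 2 nitrogen; one five-membered aromatic ring with 2 hetero atoms, one six-membered non-aromatic ring of carbon only), on an aromatic carbon. Nowhere among the measured compounds has this exact exchange been tested side by side, so there is no measured step to lean on. Given that the three measured values all sit within the scatter of one another, the step from compound 2 to compound 4 is expected to be small, with no clear direction beyond the scatter.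

Compound 4 is therefore expected to give about 750 nM, with a likely range from 300 nM to 1900 nM. The expected step is a 1.1-fold higher number from compound 2 to compound 4 (0.04 log units; within the scatter), essentially flat.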

Compound 4, inhibition constant: 890 nM
For compound 4 the middle estimate is 1.2-fold (0.07 log units) below the measured one; the measured number falls inside the stated range.
By their numbers in this assay, from the lowest: compounds 3, 2, 4 and 1 (each within the scatter of the next).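

At this position, on an aromatic carbon para to a large group, putting 4-(trifluoromethyl)-1H-pyrazol-1-yl in place of the group that carries the extra six-membered non-aromatic ring gives a 1.3-fold higher number from compound 2 to compound 4 (0.11 log units; within the scatter) in this assay, so losing that ring and gaining trifluoromethyl leaves the result within the scatter. Going by these compounds alone, compound 4 also provides the first one-place comparison on the saturated chain carbon, where propyl in place of cyclopropyl gives a 1.5-fold lower number from compound 1 to compound 4 (0.16 log units; within the scatter), so neither exchange shifts the number by more than repeat measurements could. Nothing available here explains why these two steps are so small.

From the compounds shown here alone, it remains open whether a nitrile in place of trifluoromethyl, or a chain longer than propyl on the saturated carbon, would move the number beyond the scatter. Compound 3 differs from compound 4 in more than one place, so the compounds shown cannot isolate what the oxygen link contributes compared with a nitrogen link.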